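The source may hold more compounds than are shown below. What is called first, only, known or untested is meant among the compounds shown, and "the series" means these compounds.

Compound 3 `O=C(Nc1cccc2[nH]ncc12)NC1CCOc2c(OC(F)(F)F)cccc21` gives 5 nM in a functional assay for antagonist activity at transient receptor potential cation channel subfamily V member 1 (Homo sapiens), read by calcium flux (a lower number here means a stronger inhibitor, a higher number a weaker inhibitor), the lowest of the three measured numbers; compound 1 `O=C(Nc1cccc2[nH]ncc12)N[C@H]1CCOc2cc(C(F)(F)F)ccc21` gives 43 nM, and compound 2 `CC(C)(C)c1ccc2c(c1)OCC[C@@H]2NC(=O)Nc1cccc2[nH]ncc12` gives 1200 nM, both beyond the scatter from compound 3. Among the compounds with values here, the single step measured between compounds differing in one place, a 28-fold higher number from compound 1 to compound 2 (1.45 log units; beyond the scatter), swaps one substituent for another on the same aromatic carbon of the shared core. Compound 4 `O=C(Nc1cccc2[nH]ncc12)NC1CCOc2ccccc21` differs from compound 3 by hydrogen in place of trifluoromethoxy on an aromatic carbon. Within the data shown here, no measured step removes a substituent outright, so the step from compound 1 to compound 2 bears on it only indirectly: it shows that the identity of the group on that ring moves the number in this assay by a large amount. Since compound 1 and compound 3, both substituted, give the lowest numbers, compound 4, which carries no such group, is expected to give a higher number than compound 3. The expected step in this assay is a 10-fold higher number from compound 3 to compound 4 (1.00 log units; beyond the scatter), beyond the scatter. Compound 4 is estimated at 50 nM, with a range from 10 nM to 300 nM.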

Compound 4, half-maximal inhibitory concentration: 234 nM
Beside the measured number, compound 4's estimate is 4.7-fold (0.67 log units) below it, within the range that was stated.
By their numbers in this assay, from the lowest: compound 3; then compound 1; then compound 4; then compound 2.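

In this assay, within the data shown here, a 47-fold higher number from compound 3 to compound 4 (1.67 log units; beyond the scatter) is the first step that takes a substituent away and leaves hydrogen, where the earlier step only exchanged one substituent for another. It shows that the low number of compound 3 depends on the trifluoromethoxy group on this aromatic carbon, and that the unsubstituted compound 4 serves as the reference for this position. Nothing available explains the size of this step.

Open, from the compounds shown here alone, is whether a smaller group on this carbon, such as fluorine, methoxy or methyl, would keep a number near that of compound 3, and how an amine or a carboxylic acid there would read. Also open, going by these compounds, is how trifluoromethyl and trifluoromethoxy rank on one and the same carbon.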